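This account rests on a few compounds, and the source may have more. Where it says the series, first, only, none or still open, it means among the compounds named here.

Measured so far in a functional assay on MCF7 cells (Homo sapiens) for antiproliferative activity, read by MTT assay, with a stated time of 72 h; a lower number here means a stronger inhibitor, a higher number a weaker inhibitor:
compound 1, `CC/C=C/C(=O)Nc1cc2c(N3CCc4ccccc43)ncnc2cc1O[C@@H]1CCOC1`, 8840 nM;
compound 2, `CC(C)/C=C/C(=O)Nc1cc2c(N3CCc4ccccc43)ncnc2cc1O[C@@H]1CCOC1`, 9880 nM;
compound 3, `C/C=C/C(=O)Nc1cc2c(N3CCCc4ccccc43)ncnc2cc1OC`, 12700 nM.

Compound 1 and compound 2 share a core and differ by methyl in place of hydrogen on a saturated chain carbon bound to a double-bonded chain carbon and a saturated chain carbon. This change gave a 1.1-fold higher number from compound 1 to compound 2 (0.05 log units; within the scatter). Compound 3 carries a different core; the difference between the two cores is not broken down here, and its value and those of compound 1 and compound 2 all lie within the usual scatter of one another.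

Compound 4, `CC/C=C/C(=O)Nc1cc2c(N3CCCc4ccccc43)ncnc2cc1OC`, has not yet been measured. It differs from compound 3 by methyl in place of hydrogen on a saturated chain carbon bound to a double-bonded chain carbon. The surroundings differ from the earlier case: there the carbon was also bound to a saturated chain carbon, here only to a double-bonded chain carbon, so this is the same kind of change, not the same one. The step from compound 3 to compound 4 is expected to be a 1.0-fold lower number from compound 3 to compound 4 (0.01 log units; within the scatter) because the similar change gave a 1.1-fold higher number from compound 1 to compound 2 (0.05 log units; within the scatter). Compound 4 is therefore estimated at 12500 nM in this assay, with a likely range of 6000 nM to 26000 nM.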

Compound 4, half-maximal inhibitory concentration: 2870 nM
Estimate against measurement, compound 4: 4.4-fold (0.64 log units) above; measured number below the stated range.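

In this assay, methyl in place of hydrogen gave a 4.4-fold lower number from compound 3 to compound 4 (0.65 log units; beyond the scatter), and this step did not carry over unchanged from the other core: the same change on two cores in this assay, a 1.1-fold higher number (0.05 log units; within the scatter) from compound 1 to compound 2 and a 4.4-fold lower number (0.65 log units; beyond the scatter) from compound 3 to compound 4, 4.9-fold (0.69 log units) apart, beyond the scatter of two such steps The carbon receiving the methyl also has different surroundings in the two cases, being bound to a saturated chain carbon only in the earlier one. These two pairs therefore do not show whether the gap follows the core, the chain or both, and each case rests on a single pair.

Still open, as far as these compounds go, is whether a longer chain in place of but-1-en-1-yl would extend the drop on the core of compound 3. An amine at the chain end is also untested in the compounds shown here.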